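This account rests on a few compounds, and the source may have more. Where it says the series, first, only, none or still open, it means among the compounds named here.

Within the data shown here, compound 2 `CC(C)(C)c1ccc(CNCCCNS(=O)(=O)c2cc(C(F)(F)F)cc(C(F)(F)F)c2)cc1` is one of three compounds measured in a functional assay on BXPC-3 cells (Homo sapiens) for inhibition, read by MTT assay, with a stated time of 72 h (a lower number here means a stronger inhibitor of growth, a higher number a weaker inhibitor of growth), and in this assay compound 2 gives 1400 nM. Compound 1 `O=S(=O)(NCCCNCc1cccc2ccccc12)c1cc(C(F)(F)F)cc(C(F)(F)F)c1` gives 2700 nM in this assay, and compound 3 `O=S(=O)(NCCCNCC1COc2ccccc2O1)c1cc(C(F)(F)F)cc(C(F)(F)F)c1` gives 1200 nM. Among the measured compounds shown here, compound 2 therefore stands second highest of the three numbers; its steps to the other two, a 1.9-fold lower number from compound 1 to compound 2 (0.29 log units; within the scatter) and a 1.2-fold lower number from compound 2 to compound 3 (0.07 log units; within the scatter), both lie within the scatter, and only the step of a 2.3-fold lower number from compound 1 to compound 3 (0.35 log units; beyond the scatter) is modest and beyond it. Compound 4 `O=S(=O)(NCCCNCc1ccc(-c2ccccc2)cc1)c1cc(C(F)(F)F)cc(C(F)(F)F)c1` differs from compound 2 as follows: phenyl in place of tert-butyl on an aromatic carbon. The measured steps all exchange the whole group on the saturated chain carbon bound to the amine nitrogen, whereas the present change alters a substituent on the aromatic ring of that group, so none of them matches it closely. What they do show is that exchanging this end of the shared core, from naphthalen-1-yl to 4-(tert-butyl)phenyl to 2,3-dihydro-1,4-benzodioxin-2-yl, moved the numbers in this assay only a little. Compound 4 is therefore expected to give 1300 nM in this assay, within 600 nM to 3000 nM, a step of a 1.1-fold lower number from compound 2 to compound 4 (0.03 log units; within the scatter) estimated to remain within the scatter.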

Compound 4, concentration for 50% growth inhibition: 1700 nM
Estimate against measurement, compound 4: 1.3-fold (0.12 log units) below; the measured number falls inside the stated range.
By their numbers in this assay, from the lowest: compounds 3, 2, 4 and 1 (each within the scatter of the next, the first and the last beyond it).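

The earlier steps shown here each exchanged the whole group on the saturated chain carbon, whereas this one keeps that benzyl-type attachment and alters only the substituent on an aromatic carbon, para to a large group, where phenyl, with 6 heavy atoms and one six-membered aromatic ring, enters in place of tert-butyl, with 4 heavy atoms and no ring. In this assay this gives a 1.2-fold higher number from compound 2 to compound 4 (0.08 log units; within the scatter), so compound 2 and compound 4 cannot be told apart, and this position accepts an added aromatic ring in place of the ringless group without a change that the measurement can resolve. No measurement is available that would explain this result.

Both groups at this position contain carbon only, so the compounds shown leave open how a carboxylic acid, an amine or a methoxy group on the same aromatic carbon would read in this assay. They also leave open whether a plain hydrogen at this position, or a longer chain between the two nitrogens of the shared core, would move the number beyond the scatter.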